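From a hydroxyethyl to an aminobutyl side chain

A few compounds are considered here, and "the series" means these few. Any claim that something is new, unique, unknown or untested is made for them only; others in the source may bear on it.

Going by the values given here, compound 3 `C[C@@H](O)[C@H](NC(=O)CN(c1nc(Cl)nc2[nH]cnc12)C1CC1)C(=O)O` gives 30.1% in a functional assay on the whole organism (Tail, strain ICR) with Mus musculus as the target, in the tail flick test, with a stated time of 60 min, at a dose of 25 umol/kg by the oral route (on this read-out higher numbers stand for a stronger effect at the one dose given and lower numbers for a weaker effect), the lowest of the three numbers measured so far. Compound 1 `N=C(N)NCCC[C@H](NC(=O)CN(c1nc(Cl)nc2[nH]cnc12)C1CC1)C(=O)O` gives 51%, and compound 2 `O=C(O)CNC(=O)CN(c1nc(Cl)nc2[nH]cnc12)C1CC1` gives 38.9%. The step of a number 8.8 percentage points lower from compound 2 to compound 3 (within the scatter) lies within the scatter, while the steps of a number 12.1 percentage points lower from compound 1 to compound 2 (beyond the scatter) and a number 20.9 percentage points lower from compound 1 to compound 3 (beyond the scatter) are beyond it; both of them start from the compound carrying the group of 7 heavy atoms (4 carbon, 3 nitrogen) on the chain carbon between the amide-type nitrogen and the carbonyl carbon.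

Compound 4 `NCCCC[C@H](NC(=O)CN(c1nc(Cl)nc2[nH]cnc12)C1CC1)C(=O)O` has not yet been measured in this assay. It differs from compound 3 by 4-aminobutyl in place of 1-hydroxyethyl on a saturated chain carbon bound to an amide-type nitrogen and a carbonyl carbon. The step that bears most directly on this change is a number 20.9 percentage points lower from compound 1 to compound 3 (beyond the scatter), which was modest but beyond the scatter, and which went from a longer side chain bearing nitrogen to the 1-hydroxyethyl group. Among the compounds with values here, compound 4 again carries a longer side chain bearing nitrogen, so a rise of roughly that order is expected, though with only one such comparison the size is uncertain. Compound 4 is expected to give about 45%, with a range from 30% to 60%. For compound 4 the expected step is a number 14.9 percentage points higher from compound 3 to compound 4 (beyond the scatter).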

Compound 4, a percentage reported as activity, at one dose (the size of the read-out at that dose, not a potency): 53.8%
Compound 4: the middle estimate sits 8.8 percentage points below what was measured; low and high end bracket the measured number.
By their numbers in this assay, from the lowest: compounds 3 and 2 (each within the scatter of the next); then compounds 1 and 4 (each within the scatter of the next).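

In this assay the change to 4-aminobutyl on the saturated chain carbon bound to an amide-type nitrogen and a carbonyl carbon gives a number 23.7 percentage points higher from compound 3 to compound 4 (beyond the scatter) and, set against plain hydrogen at that place, a number 14.9 percentage points higher from compound 2 to compound 4 (beyond the scatter) as well, so the gap first seen with compound 1 now has a second example in a side chain of different make-up. The outer end of the chain counts for little in this series: a number 2.8 percentage points higher from compound 1 to compound 4 (within the scatter) is all that separates the two nitrogen-bearing chains. Nothing measured here explains why these side chains differ.

Compounds 1 and 4 carry chain length and terminal nitrogen together, so the compounds shown do not separate the two, and a plain butyl chain, a shorter amine chain or a longer one would be needed to tell them apart. Going by these compounds, whether a carboxylic acid or an amide at the chain end would fall with the first pair or the second also stays open.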